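The source may hold more compounds than are shown below. What is called first, only, known or untested is meant among the compounds shown, and "the series" means these compounds.

In an assay on HEK293 cells for activation of Kir3.1/Kir3.2 (Homo sapiens), read by thallium flux (on this read-out higher numbers stand for larger maximal responses and lower numbers for smaller maximal responses), compound 1 (`Cc1cc(NC(=O)Cn2nnc(-c3ccccc3)n2)n(C2CCS(=O)(=O)CC2)n1`) gives > 25%, which is a limit of the assay and not a number.
Compound 2 (`Cc1cc(NC(=O)Cn2nnc(-c3ccccc3)n2)n(Cc2ccccc2)n1`) gives 74%.
Compound 3 (`Cc1cc(NC(=O)Cn2nnc(-c3ccc(F)cc3)n2)n(C2CCCCC2)n1`) gives 92%.

Compound 3 therefore stands highest of the two numbers in this assay; its nearest neighbour is compound 2, whose value lies lower by a gap beyond the usual scatter. For the measured compounds named here, the only step between measured compounds, a step that the limit leaves unreadable from compound 1 to compound 2, is one that the limit leaves unreadable, as the limit of > 25% in this assay, at which 1 of the 3 values shown sits, shows, so its size cannot be taken from the data.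

Compound 4 (`Cc1ccc(-c2nnn(CC(=O)Nc3cc(C)nn3C3CCCCC3)n2)cc1`) differs from compound 3 in one place: methyl in place of fluoro on an aromatic carbon. Going by the values given here, none of the measured steps touches this position or this exchange; the one measured step concerns the group on the aromatic nitrogen and is in any case unreadable. With nothing measured to bear on the change, the expectation for compound 4 in this assay is a step of no size beyond the scatter, in neither direction, that is a number 7 percentage points lower from compound 3 to compound 4 (within the scatter).

Compound 4 is thus estimated to reach 85% in this assay, within a range from 60% to 105%.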

Compound 4, largest response reached (Emax), in percent of the reference or control that the assay uses: 86%
Beside the measured number, compound 4's estimate is 1 percentage points below it; low and high end bracket the measured number.
By their numbers in this assay, from the lowest: compound 2; then compounds 4 and 3 (each within the scatter of the next).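

For the compounds shown here, the exchange of 4-fluorophenyl for 4-methylphenyl gives the first readable measurement at this position, and in this assay it amounts to a number 6 percentage points lower from compound 3 to compound 4 (within the scatter), so on this read-out the two compounds cannot be told apart. Going by these compounds alone, the earlier compounds could not show this: their only step concerns the group on the aromatic nitrogen, not the six-membered aromatic ring, and that step cannot be read. The result therefore shows that, with cyclohexyl on the aromatic nitrogen, fluoro and methyl para to a large group are interchangeable in this assay, though nothing shown gives a cause for this outcome.

What the compounds leave open is whether this holds only for these two small groups, or also for a group such as an amine, a methoxy group or a carboxylic acid at the same place on the ring. Also open is whether the same exchange would come out alike with benzyl in place of cyclohexyl on the aromatic nitrogen, as in compound 2, since only one such pair is shown here.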